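Chloro to Bromo on the Aryl Ring of Compound 3

The source may hold more compounds than are shown below. What is called first, only, known or untested is meant among the compounds shown, and "the series" means these compounds.

Compound 3 `Oc1ccccc1/C=N/c1nnc(SCc2nnc(-c3ccc(Cl)cc3)o2)s1` gives 2840 nM in a functional assay on SMMC-7721 cells (Homo sapiens) for inhibition, read by CCK-8 assay (a lower number here means a stronger inhibitor, a higher number a weaker inhibitor), the lowest of the three numbers measured. Compound 1 `Oc1ccccc1/C=N/c1nnc(SCc2nnc(-c3ccc(F)cc3)o2)s1` gives 13100 nM, and compound 2 `Oc1ccccc1/C=N/c1nnc(SCc2nnc(-c3ccccc3Cl)o2)s1` gives 31800 nM. The step from compound 1 to compound 3 a 4.6-fold lower number from compound 1 to compound 3 (0.66 log units; beyond the scatter) is the one that bears most directly on what follows, since it swaps one halogen for another at the same place on the ring. The other two steps of a 2.4-fold higher number from compound 1 to compound 2 (0.39 log units; beyond the scatter) and an 11-fold lower number from compound 2 to compound 3 (1.05 log units; beyond the scatter) move the chlorine to a different part of the ring and are less informative here.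

Compound 4 `Oc1ccccc1/C=N/c1nnc(SCc2nnc(-c3ccc(Br)cc3)o2)s1` differs from compound 3 in one place: bromo in place of chloro on an aromatic carbon. Given the modest improvement when chloro replaced fluoro a 4.6-fold lower number from compound 1 to compound 3 (0.66 log units; beyond the scatter), a further, smaller step in the same direction is expected, though it could equally fall within the scatter. Compound 4 is therefore expected to give about 2000 nM, within a range of 700 nM to 6000 nM, which would mean an estimated step of a 1.4-fold lower number from compound 3 to compound 4 (0.15 log units; within the scatter).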

Compound 4, half-maximal inhibitory concentration: 18000 nM
Compound 4: the middle estimate sits 9.0-fold (0.95 log units) below what was measured, outside the stated range (above it).
By their numbers in this assay, from the lowest: compound 3; then compounds 1, 4 and 2 (each within the scatter of the next, the first and the last beyond it).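

In this assay, the halogens at this place on the ring do not follow a steady trend: going from chloro to bromo reverses the gain seen from fluoro to chloro (a 6.3-fold higher number from compound 3 to compound 4 (0.80 log units; beyond the scatter)). Bromo and fluoro end up within the scatter of each other (a 1.4-fold higher number from compound 1 to compound 4 (0.14 log units; within the scatter)), and the 4-bromophenyl and 2-chlorophenyl groups do too (a 1.8-fold lower number from compound 2 to compound 4 (0.25 log units; within the scatter)), so among these four compounds only the 4-chlorophenyl group of compound 3 stands apart. Nothing measured here offers a reason for this difference between chloro and bromo.

The compounds shown leave open whether chloro is unusual at this place, or whether a methyl, methoxy or trifluoromethyl group there would match it. They also leave open how bromo would behave elsewhere on the ring.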